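Swapping a Pyrazole for tert-Butyl on the Hydroxy Side Chain

A few compounds are considered here, and "the series" means these few. Any claim that something is new, unique, unknown or untested is made for them only; others in the source may bear on it.

Of the compounds shown here, three built on one shared core have so far been measured in an ADME assay on Caco-2 cells (Homo sapiens) for permeability, read by LC-MS, in the apical to basolateral direction, with a stated time of 60 min, at pH 6.5; on this read-out lower numbers stand for lower permeability and higher numbers for higher permeability. Compound 1 `CC(C)(C)C[C@@H](O)C(=O)N1OCC[C@H]1C(=O)NCc1cc(Cl)ccc1-n1cnnn1` gives 25 10^-6 cm/s. Compound 2 `O=C([C@H](O)c1ccccc1)N1CC[C@@H]2C[C@@]21C(=O)NCc1cc(Cl)ccc1-n1cnnn1` gives 2.6 10^-6 cm/s. Compound 3 `O=C(NCc1cc(Cl)ccc1-n1cnnn1)[C@@H]1[C@H]2C[C@H]2CN1C(=O)[C@H](O)Cn1cccn1` gives 0.31 10^-6 cm/s, the lowest of the three numbers; compound 2 lies clearly above it and compound 1 higher still, and both of these gaps are beyond the usual scatter of repeated measurements.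

Compound 4 `CC(C)(C)C[C@@H](O)C(=O)N1C[C@@H]2C[C@@H]2[C@H]1C(=O)NCc1cc(Cl)ccc1-n1cnnn1` has not yet been measured in this assay. It keeps the core of compound 3 and differs from it in one place: tert-butyl in place of 1H-pyrazol-1-yl on a saturated chain carbon, two bonds along the chain from a carbonyl carbon and an oxygen on a saturated carbon. A five-membered aromatic ring carrying two hydrogen-bond acceptors thus gives way to a plain saturated group with none.

Among the compounds with values here, no measured pair shows this exact change, so the expectation rests on the wider picture. Compound 1, which carries the same neopentyl side chain on a different core, gives 25 10^-6 cm/s in this assay. On that basis the step of a 32-fold higher number from compound 3 to compound 4 (1.51 log units; beyond the scatter) is expected to be upward and well beyond the scatter. Compound 4 is therefore estimated at 10 10^-6 cm/s, with a likely range from 3 10^-6 cm/s to 30 10^-6 cm/s.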

Compound 4, apparent permeability: 25 10^-6 cm/s
Beside the measured number, compound 4's estimate is 2.5-fold (0.40 log units) below it; the range from low to high includes it.
By their numbers in this assay, from the lowest: compound 3; then compound 2; then compounds 1 and 4 (each within the scatter of the next).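

On the core of compound 3, the side-chain position two bonds along from the carbonyl carbon is now shown to matter a great deal in this assay: tert-butyl in place of 1H-pyrazol-1-yl gives an 81-fold higher number from compound 3 to compound 4 (1.91 log units; beyond the scatter), a large step beyond the scatter. The earlier compounds shown here differed from one another in more than one place, so they could not show what this position does on its own, whereas this pair differs only here and ties the whole gap to this single change. Nothing measured here explains why the change has so large an effect.

This one swap removes the aromatic ring and its two nitrogen atoms together and brings in a branched carbon group, so the compounds shown cannot tell which part of the change carries the step. As far as these compounds go, a cyclopentyl group, an imidazole ring or a short chain ending in an amine at the same position would help to separate these parts, and it also remains open whether the same swap gives a step of similar size on other cores.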